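The source may report more compounds than this note shows. Statements on the series, on what has been measured and on what is new or still open speak of the compounds shown alone.

Compound 3 `Cc1ccc(C(F)(F)F)cc1COc1cc(NC(=O)c2ccc3ccccc3c2)ccc1N(C)S(C)(=O)=O` gives the highest number of the three measured compounds in a functional assay on SK-BR-3 cells (Homo sapiens) for antiproliferative activity, read by MTT assay, with a stated time of 48 h; on this read-out higher numbers stand for weaker inhibition and lower numbers for stronger inhibition: compound 3 gives 18400 nM. Compound 1 `COc1ccc(C(=O)Nc2ccc(N(C)S(C)(=O)=O)c(OCc3cc(C(F)(F)F)ccc3C)c2)cc1OC` sits close by, with compound 1 giving 16900 nM and a 1.1-fold higher number from compound 1 to compound 3 (0.04 log units; within the scatter). Compound 2 `Cc1ccc(C(F)(F)F)cc1COc1cc(NC(=O)c2ccc(I)cc2)ccc1N(C)S(C)(=O)=O` gives 3500 nM, and a 5.3-fold higher number from compound 2 to compound 3 (0.72 log units; beyond the scatter). Compound 4 `COc1ccc(OC)c(COc2cc(NC(=O)c3ccc4ccccc4c3)ccc2N(C)S(C)(=O)=O)c1` differs from compound 3 by 2,5-dimethoxyphenyl in place of 2-methyl-5-(trifluoromethyl)phenyl on a saturated chain carbon bound to an oxygen on an aromatic ring. All three measured steps change the ring on the carbonyl carbon, not this side of the shared core, so none of them bears on the change from compound 3 to compound 4. With no guide, compound 4 is expected to show a 1.0-fold lower number from compound 3 to compound 4 (0.01 log units; within the scatter), a step not beyond the scatter. The estimate for compound 4 in this assay is 18000 nM, within a range from 5000 nM to 65000 nM.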

Compound 4, half-maximal inhibitory concentration: 16.6 nM
Estimate against measurement, compound 4: 1100-fold (3.04 log units) above; measured number outside the range, below it.
By their numbers in this assay, from the lowest: compound 4; then compound 2; then compounds 1 and 3 (each within the scatter of the next).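

In this assay, changing 2-methyl-5-(trifluoromethyl)benzyl to 2,5-dimethoxybenzyl on the shared core gives a 1100-fold lower number from compound 3 to compound 4 (3.04 log units; beyond the scatter). This far exceeds the largest step from changing the ring on the carbonyl carbon, a 5.3-fold higher number from compound 2 to compound 3 (0.72 log units; beyond the scatter), so this position can matter greatly in this series. Nothing shown here explains the size of the step.

Going by these compounds, it remains open whether both methoxy groups are needed, or whether a benzyl group with a single methoxy group would do as well. On these data alone, it is also open whether 2,5-dimethoxybenzyl gives a similar step with 4-iodophenyl on the carbonyl carbon.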